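From 4-fluorophenyl to 3-nitrophenyl on the shared core

This account rests on a few compounds, and the source may have more. Where it says the series, first, only, none or still open, it means among the compounds named here.

Compound 1 (`O=[N+]([O-])c1cccc(-c2nn(-c3ccccc3)cc2C(Nc2nc3ccccc3s2)c2c(O)ccc3ccccc23)c1`) at 32000 nM and compound 2 (`Cc1ccc2nc(NC(c3cn(-c4ccccc4)nc3-c3cccc([N+](=O)[O-])c3)c3c(O)ccc4ccccc34)sc2c1`) at 57400 nM lie within the scatter of compound 3 (`Oc1ccc2ccccc2c1C(Nc1nc2ccc(Cl)cc2s1)c1cn(-c2ccccc2)nc1-c1ccc(F)cc1`), which gives 32200 nM in a functional assay on A549 cells (Homo sapiens) for antiproliferative activity, read by MTT assay, with a stated time of 48 h (a lower number here means a stronger inhibitor, a higher number a weaker inhibitor), and so holds no clear rank among them. Compound 4 (`O=[N+]([O-])c1cccc(-c2nn(-c3ccccc3)cc2C(Nc2nc3ccc(Cl)cc3s2)c2c(O)ccc3ccccc23)c1`) has 3-nitrophenyl in place of 4-fluorophenyl on an aromatic carbon. For the measured compounds named here, the only measured step (a 1.8-fold higher number from compound 1 to compound 2 (0.25 log units; within the scatter)) is methyl in place of hydrogen on an aromatic carbon, a different change, and it stays within the scatter. Compound 1 already carries 3-nitrophenyl and gives 32000 nM against compound 3 at 32200 nM with its 4-fluorophenyl, although the two also differ elsewhere, so no step beyond the scatter is expected in this assay here. The expected step (a 1.1-fold higher number from compound 3 to compound 4 (0.04 log units; within the scatter)) is therefore small. Compound 4 is estimated at 35000 nM (expected range 17000 nM to 70000 nM).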

Compound 4, half-maximal inhibitory concentration: 42500 nM
Estimate against measurement, compound 4: 1.2-fold (0.08 log units) below; the range from low to high includes it.
By their numbers in this assay, from the lowest: compounds 1, 3, 4 and 2 (each within the scatter of the next).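

In this assay, for the compounds shown here, 3-nitrophenyl in place of 4-fluorophenyl gives a 1.3-fold higher number from compound 3 to compound 4 (0.12 log units; within the scatter), the first direct reading of this change at this position on an otherwise unchanged compound, and the aryl swap leaves the number within the scatter. The chloro compound also stays within the scatter of its two neighbours on the other ring, with a 1.3-fold higher number from compound 1 to compound 4 (0.12 log units; within the scatter) for chloro in place of hydrogen and a 1.4-fold lower number from compound 2 to compound 4 (0.13 log units; within the scatter) for chloro in place of methyl.

From the compounds shown here alone, whether an amine or a carboxylic acid on this carbon of the five-membered ring would move the number beyond the scatter remains open. No measured evidence bears on these results.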